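The source may report more compounds than this note shows. Statements on the series, on what has been measured and on what is new or still open speak of the compounds shown alone.

Compound 1, whose structure is `CCN(C(=O)CC(CC(=O)NCCN1CCCC1)c1ccc(Cl)cc1)C1Cc2ccccc2C1`, is the reference point of this small series. In a functional assay on L02 cells (Homo sapiens) for inhibition (a lower number here means a stronger inhibitor, a higher number a weaker inhibitor), compound 1 gives 54200 nM. Compound 2, `CN(C(=O)CC(CC(=O)NCCN1CCCC1)c1ccc(Cl)cc1)C1Cc2ccccc2C1`, differs from it by hydrogen in place of methyl on a saturated chain carbon bound to an amide-type nitrogen, and in this assay compound 2 gives 81500 nM, so that the step reads a 1.5-fold higher number from compound 1 to compound 2 (0.18 log units; within the scatter). Compound 3, `CCN(CC)CCNC(=O)CC(CC(=O)N(CC)C1Cc2ccccc2C1)c1ccc(Cl)cc1`, carries a different core, the two cores being set apart by diethylamino in place of pyrrolidin-1-yl on a saturated chain carbon, two bonds along the chain from an amide-type nitrogen; in this assay compound 3 gives 78400 nM, and the step reads a 1.4-fold higher number from compound 1 to compound 3 (0.16 log units; within the scatter).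

Compound 4, `CCN(CC)CCNC(=O)CC(CC(=O)N(C)C1Cc2ccccc2C1)c1ccc(Cl)cc1`, has not yet been measured. Among the compounds with values here, it differs from compound 3 by hydrogen in place of methyl on a saturated chain carbon bound to an amide-type nitrogen, which is the same change as the one from compound 1 to compound 2, made in the same place. Since that earlier step came out as a 1.5-fold higher number from compound 1 to compound 2 (0.18 log units; within the scatter), the step from compound 3 to compound 4 is expected to be of a like small size, estimated as a 1.4-fold higher number from compound 3 to compound 4 (0.15 log units; within the scatter). On that basis compound 4 is estimated to give 110000 nM in this assay, with an expected range from 60000 nM to 220000 nM.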

Compound 4, half-maximal inhibitory concentration: 56500 nM
Beside the measured number, compound 4's estimate is 1.9-fold (0.29 log units) above it, outside the stated range (below it).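

In this assay, hydrogen in place of methyl on a saturated chain carbon bound to an amide-type nitrogen gives a 1.4-fold lower number from compound 3 to compound 4 (0.14 log units; within the scatter), and set against the same change on the core of compound 1 it shows no real difference: the same change on two cores in this assay, a 1.5-fold higher number (0.18 log units; within the scatter) from compound 1 to compound 2 and a 1.4-fold lower number (0.14 log units; within the scatter) from compound 3 to compound 4, 2.1-fold (0.32 log units) apart, within the scatter of two such steps. Diethylamino in place of pyrrolidin-1-yl gives a 1.4-fold lower number from compound 2 to compound 4 (0.16 log units; within the scatter), and this change likewise reads alike on both cores: the same change on two cores in this assay, a 1.4-fold higher number (0.16 log units; within the scatter) from compound 1 to compound 3 and a 1.4-fold lower number (0.16 log units; within the scatter) from compound 2 to compound 4, 2.1-fold (0.32 log units) apart, within the scatter of two such steps. The two changes are therefore compatible with carrying over from one core to the other, but every step here lies within the scatter, so the data do not show that either change has any effect, give no weight to the differing directions of the steps, and cannot test whether a larger effect would carry over.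

The compounds shown leave open how a longer chain such as propyl in place of the ethyl, or a morpholin-4-yl group in place of pyrrolidin-1-yl, would read in this assay. Going by these compounds, whether either group would move the number beyond the scatter also remains open.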